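The compounds below may be only part of what the source reports. "The series", "measured", "known", "first", "only" and "open" are said of these compounds alone.

Measured compounds:
- compound 1, `COc1cc2occ(-c3csc4ccccc34)c(=O)c2cc1OC`: in a functional assay on A549 cells (Homo sapiens) for antiproliferative activity, read by sulforhodamine B assay, with a stated time of 72 h (on this read-out lower numbers stand for stronger inhibition and higher numbers for weaker inhibition), compound 1 gives > 10000 nM, a limit of the assay and not a number.
- compound 2, `COc1cc2c(=O)c(-c3csc4ccccc34)coc2c(OC)c1OC`: in this assay compound 2 gives > 10000 nM, again a limit and not a number.
- compound 3, `COc1cc(O)c(C(=O)/C=C/c2csc3ccccc23)cc1OC`: in this assay compound 3 gives 450 nM.

Compound 1 and compound 2 share one core; compound 2 differs from compound 1 by methoxy in place of hydrogen on an aromatic carbon. The step that the two limits leave unreadable from compound 1 to compound 2 cannot be sized because of the limit of > 10000 nM in this assay, at which 2 of the 3 values shown sit. Compound 3 is built on a different core; the difference between the two cores is not broken down here. Going by the values given here, of the three values, only that of compound 3 is a number.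

Compound 4, `COc1cc(O)c(C(=O)/C=C/c2csc3ccccc23)c(OC)c1OC`, is not yet measured. It differs from compound 3 by methoxy in place of hydrogen on an aromatic carbon. This is the same kind of change as from compound 1 to compound 2, but the surroundings differ: in compound 2 the methoxy enters on a ring that is part of a fused or bridged system of two rings, ortho to a fused ring and meta to a fused ring, while in compound 4 it enters ortho to a large group and meta to a hydroxy group; in both it sits ortho to a methoxy group and meta to a methoxy group.

Among the compounds with values here, the one measured instance of this change gives no readable size, so the expectation for compound 4 rests on compound 3 alone, which gives 450 nM in this assay. Compound 4 is therefore expected to sit near compound 3, with an estimated step of a 1.8-fold higher number from compound 3 to compound 4 (0.25 log units; within the scatter). The estimate for compound 4 is 800 nM, expected to lie between 200 nM and 4000 nM.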

Compound 4, half-maximal inhibitory concentration: 5300 nM
Compound 4: the middle estimate sits 6.6-fold (0.82 log units) below what was measured; measured number outside the range, above it.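

On the core of compound 3, methoxy in place of hydrogen on an aromatic carbon gives a 12-fold higher number from compound 3 to compound 4 (1.07 log units; beyond the scatter) in this assay, so on this core the change clearly weakens inhibition in this pair. Going by these compounds alone, on the core of compound 1 the same change cannot be sized, because compound 1 and compound 2 both sit at a limit and not at a number: the limit of > 10000 nM in this assay, at which 2 of the 4 values shown sit. The series therefore holds only one readable instance of this change, which shows its size on one core but does not show whether that size, or even its direction, carries over to the other core.

From the compounds shown here alone, it remains open whether the loss belongs to methoxy itself or would also follow from another group on the same aromatic carbon, such as a fluorine atom, an amine or a longer chain like ethoxy. Also open, going by these compounds, is whether an amine or a carboxylic acid elsewhere on the core of compound 1 would bring that series off its limit, which would allow the methoxy change to be sized on a second core.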